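Phenyl in Place of Bromomethoxyphenyl on an Inactive Anilide

This account rests on a few compounds, and the source may have more. Where it says the series, first, only, none or still open, it means among the compounds named here.

Of the compounds shown here, three have been tested in an assay on isolated protein for inhibition of thiosulfate sulfurtransferase (Homo sapiens), with a stated time of 60 min, in the absence of a further agent; a higher number here means a weaker inhibitor, a lower number a stronger inhibitor. Compound 1 `O=C(Nc1ccccc1)c1cc(Br)cc(Br)c1` returned only a limit of > 100000 nM. Compound 3 `COc1ccc(Br)cc1C(=O)Nc1ccccc1` likewise gave only a limit, > 100000 nM. Compound 2 `COc1ccc(Br)cc1C(=O)Nc1ccc(Sc2nc3ccccc3s2)cc1` also sits at a limit of > 100000 nM in this assay. Compound 2 therefore stands nowhere apart from the other two: every value is a limit rather than a number, (the limit of > 100000 nM in this assay, at which 3 of the 3 values shown sit), and no order among the three can be read.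

Compound 4 `O=C(Nc1ccc(Sc2nc3ccccc3s2)cc1)c1ccccc1` differs from compound 2 in a single place, (phenyl in place of 5-bromo-2-methoxyphenyl on a carbonyl carbon), that is, phenyl in place of 5-bromo-2-methoxyphenyl on a carbonyl carbon. For the measured compounds named here, no measured step between any two of the compounds bears on this change, since all values shown are limits. Compound 4 is expected to give 150000 nM in this assay, within 30000 nM to 1000000 nM, and will most probably again be reported only as a limit. The expected step is a step that the limit leaves unreadable from compound 2 to compound 4, none beyond the scatter.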

Compound 4, half-maximal inhibitory concentration: > 100000 nM
Compound 4 gave a limit, no number; the forecaster's own chance of this, stated with the estimate: 85%; the middle value is on the limit's open side.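

Compound 2 and compound 4 both gave only a limit, so no step between them can be read: the limit of > 100000 nM in this assay, at which 4 of the 4 values shown sit.

The compounds shown leave open whether phenyl and 5-bromo-2-methoxyphenyl differ at all on this carbonyl carbon, and what structure would give a measurable value.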